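The compounds below may be only part of what the source reports. "The series", "measured", "known", "first", "only" and "open" are said of these compounds alone.

Compounds measured in a functional assay on MKN-45 cells (Homo sapiens) for cytotoxicity, read by MTT assay, with a stated time of 72 h; on this read-out higher numbers stand for weaker inhibition and lower numbers for stronger inhibition:
compound 1 `COc1cc2c(Oc3ccc(NC(=O)N/N=C/c4ccc(C(F)(F)F)cc4)cc3F)ccnc2cc1OCCCN1CCCCC1` gives 630 nM;
compound 2 `COc1cc2c(Oc3ccc(NC(=O)N/N=C/c4ccc(Cl)cc4Cl)cc3F)ccnc2cc1OCCCN1CCCCC1` gives 460 nM;
compound 3 `COc1cc2c(Oc3ccc(NC(=O)N/N=C/c4ccc(O)cc4)cc3F)ccnc2cc1OCCCN1CCCCC1` gives 850 nM.

All three share one core and differ only in the aromatic ring on the carbon with a double bond to nitrogen. Every swap of that ring stayed within the scatter: a 1.4-fold lower number from compound 1 to compound 2 (0.14 log units; within the scatter), a 1.3-fold higher number from compound 1 to compound 3 (0.13 log units; within the scatter) and a 1.8-fold higher number from compound 2 to compound 3 (0.27 log units; within the scatter). Compound 3 therefore stands in one cluster with compound 1 and compound 2.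

Compound 4 `COc1cc2c(Oc3ccc(NC(=O)N/N=C/c4cccs4)cc3F)ccnc2cc1OCCCN1CCCCC1` carries the next change: thiophen-2-yl in place of 4-hydroxyphenyl on a carbon with a double bond to nitrogen. For the measured compounds named here, no measured step brings in a five-membered ring with a sulfur, so the only guide is that the three ring swaps seen so far moved nothing beyond the scatter. The expected step is a 1.3-fold lower number from compound 3 to compound 4 (0.12 log units; within the scatter). For compound 4 the estimate in this assay is 650 nM, with a range from 250 nM to 1700 nM.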

Compound 4, half-maximal inhibitory concentration: 740 nM
Compound 4: the middle estimate sits 1.1-fold (0.06 log units) below what was measured; low and high end bracket the measured number.
By their numbers in this assay, from the lowest: compounds 2, 1, 4 and 3 (each within the scatter of the next).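

In this assay a five-membered aromatic ring with a sulfur fits the same pattern as the six-membered rings on the carbon with a double bond to nitrogen: thiophen-2-yl gives (a 1.1-fold lower number from compound 3 to compound 4 (0.06 log units; within the scatter)), (a 1.6-fold higher number from compound 2 to compound 4 (0.21 log units; within the scatter)) and (a 1.2-fold higher number from compound 1 to compound 4 (0.07 log units; within the scatter)). Across compounds 1 to 4, neither the smaller ring of 5 heavy atoms nor the loss of the hydrogen-bond donor of compound 3 moves the number beyond the scatter. Nothing available explains this flat picture. Still open, going by these compounds, is whether a ring carrying an amine or a carboxylic acid would shift the number beyond the scatter. The same question stands for a longer chain in place of the ring.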